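A few compounds are considered here, and "the series" means these few. Any claim that something is new, unique, unknown or untested is made for them only; others in the source may bear on it.

Compound 1 `Cc1ccc(S/C(=C/c2ccc(Oc3ccccc3)cc2)C(=O)c2ccc(Cl)cc2)cc1` and compound 2 `Cc1ccc(S/C(=C/c2ccc(Oc3ccccc3)cc2)C(=O)c2ccc(Br)cc2)cc1` share one core and differ only in a halogen on the carbonyl-bearing ring. In a functional assay on DU-145 cells (Homo sapiens) for inhibition, read by trypan blue exclusion, with a stated time of 96 h (a higher number here means a weaker inhibitor of growth, a lower number a stronger inhibitor of growth), compound 2 gives 1000 nM, while compound 1 gives 10000 nM; the change chloro in place of bromo on an aromatic carbon produced a 10-fold higher number from compound 2 to compound 1 (1.00 log units; beyond the scatter). Compound 3 `CSc1ccc(/C=C(/SCc2ccc(Br)cc2)C(=O)c2ccc(C(=O)O)cc2)cc1` is built on a different core, and how the two cores differ is not broken down here; in this assay compound 3 gives 10000 nM, level with compound 1 at the digits shown. Compound 4 `CSc1ccc(/C=C(/SCc2ccc(Cl)cc2)C(=O)c2ccc(C(=O)O)cc2)cc1` repeats the halogen swap on the core of compound 3, as chloro in place of bromo on an aromatic carbon; the place described is the same in both cases, though the ring that carries the halogen belongs to a different arm of the molecule. Among the compounds with values here, the only measured example of this swap weakened growth inhibition, so a step of similar direction is expected, a 2.0-fold higher number from compound 3 to compound 4 (0.30 log units; within the scatter), resting on the move from compound 2 to compound 1 and tempered because compound 3 already gives 10000 nM. Compound 4 is therefore estimated at 20000 nM in this assay, most plausibly between 7000 nM and 100000 nM.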

Compound 4, concentration for 50% growth inhibition: > 100000 nM
Compound 4: no number, only a limit (the forecaster's own chance of this, stated with the estimate: 35%); middle value at least 5.0-fold (0.69 log units) from the limit.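

Compound 4 gives > 100000 nM in this assay, which is a limit of the assay and not a number. Chloro in place of bromo on an aromatic carbon gave an at least 10-fold higher number from compound 3 to compound 4 (1.00 log units; beyond the scatter), so on both cores the swap moves toward weaker growth inhibition, and the direction carries over from one core to the other: the same change on two cores in this assay, a 10-fold higher number (1.00 log units; beyond the scatter) from compound 2 to compound 1 and an at least 10-fold higher number (1.00 log units; beyond the scatter) from compound 3 to compound 4; the limit leaves it open whether they differ. Within the data shown here, this rests on only two pairs, with the halogen on a different arm of the molecule in each, and it does not show that the step has the same size on both cores, since the true value of compound 4 stays unknown: the limit of > 100000 nM in this assay, at which 1 of the 4 values shown sits.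

As far as these compounds go, only bromo and chloro are compared at this place, so it remains open whether fluoro, iodo or a methyl group would continue the same trend on either core. From the compounds shown here alone, it is also open whether the swap would behave the same way on the core of compound 4 if an ester or an amide stood in place of the carboxylic acid.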